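The source may hold more compounds than are shown below. What is called first, only, known or untested is meant among the compounds shown, and "the series" means these compounds.

In a functional assay on RAW264.7 cells (Mus musculus) for inhibition, read by Griess assay, with a stated time of 20 h (a lower number here means a stronger inhibitor, a higher number a weaker inhibitor), compound 1 `CCCNC(=O)c1ccc(-n2cc(CCC(C)C)nn2)cc1O` gives > 20000 nM, which is a limit of the assay and not a number. Compound 3 `CC(C)CCc1cn(-c2ccc(C(=O)N3CCCCC3)c(O)c2)nn1` gives > 20000 nM, also a limit. Within the data shown here, the one measured step, a step that the two limits leave unreadable from compound 1 to compound 3, therefore has no readable size. Compound 4 `O=C(c1ccc(-n2cc(-c3cc(F)cc(F)c3)nn2)cc1O)N1CCCCC1` changes compound 3 in one place: 3,5-difluorophenyl in place of isopentyl on an aromatic carbon. Compound 2 `CCCNC(=O)c1ccc(-n2cc(-c3cc(C(F)(F)F)cc(C(F)(F)F)c3)nn2)cc1O`, which also bears a substituted phenyl ring on that aromatic carbon, gives > 20000 nM, again a limit. The whole set thus sits together: the limit of > 20000 nM in this assay, at which 3 of the 3 values shown sit. On this evidence, no step beyond the usual scatter is expected in this assay, in either direction. The expected change, a step that the limit leaves unreadable from compound 3 to compound 4, is only an estimate. For compound 4 the estimated value is 25000 nM, with an expected range of 10000 nM to 60000 nM.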

Compound 4, half-maximal inhibitory concentration: > 20000 nM
Compound 4 gave a limit, no number (the forecaster's own chance of this, stated with the estimate: 75%); the middle value does not contradict the limit.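

The step from compound 3 to compound 4 cannot be read: each compound gives only a limit of the assay, not a number. The compounds shown leave open which structural change, if any, would give a measurable value in this assay.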